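A few compounds are considered here, and "the series" means these few. Any claim that something is new, unique, unknown or untested is made for them only; others in the source may bear on it.

In a functional assay on NUGC-3 cells (Homo sapiens) for antiproliferative activity, read by sulforhodamine B assay (a higher number here means a weaker inhibitor of growth, a lower number a stronger inhibitor of growth), three related compounds have been measured so far, and none of them gives a number. Compound 1 (`COc1cccc(OCCC(C)(C)C)c1C(=O)/C=C/c1ccc(O)cc1`) reaches only a limit, > 30000 nM. Compound 2 (`CC(C)=CCOc1cccc(O)c1C(=O)/C=C/c1ccc(O)cc1`) also reaches only a limit, > 30000 nM. Compound 3 (`O=C(/C=C/c1ccc(O)cc1)c1c(O)cccc1OCCC1CCCCC1`) likewise stands at a limit, > 30000 nM, so its place relative to the other two cannot be read.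

Compound 4 (`CCCCOc1cccc(O)c1C(=O)/C=C/c1ccc(O)cc1`) differs from compound 3 in the chain on the oxygen: ethyl in place of cyclohexyl on a saturated chain carbon, two bonds along the chain from an oxygen on an aromatic ring. This places ethyl in place of cyclohexyl on a saturated chain carbon, two bonds along the chain from an oxygen on an aromatic ring, so that 2-cyclohexylethoxy becomes butoxy.

Among the compounds with values here, the one measured step that bears on this chain is a step that the two limits leave unreadable from compound 2 to compound 3, and it offers no size to carry over. The remaining guide is the limit of > 30000 nM in this assay, at which 3 of the 3 values shown sit. On that evidence, no step beyond the usual scatter can be expected in this assay, and no direction can be named. The expected result is a number no higher from compound 3 to compound 4 (the limit leaves the size open). Compound 4 is estimated at 30000 nM, with an expected range from 12000 nM to 60000 nM, and it may well be reported only as a limit.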

Compound 4, concentration for 50% growth inhibition: > 30000 nM
Compound 4: a limit, no number (the forecaster's own chance of this, stated with the estimate: 70%); the middle value lies on the limit itself.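

In this assay compound 4 reaches only a limit, > 30000 nM. Its steps from compound 2 and from compound 3 cannot be read, as all three compounds stand at limits. The compounds shown leave open whether any chain on the oxygen of the shared core gives a measurable number in this assay: the limit of > 30000 nM in this assay, at which 4 of the 4 values shown sit.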